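The compounds below may be only part of what the source reports. "The series", "measured", "known", "first", "only" and "open" are said of these compounds alone.

Measured so far:
Compound 1 `Nc1ncnn2c([C@@H]3O[C@H](CO)[C@@H](O)[C@H]3O)cc(-c3ccccc3F)c12`: in a functional assay on LN-229 cells (Homo sapiens) for antiproliferative activity, with a stated time of 72 h (a lower number here means a stronger inhibitor, a higher number a weaker inhibitor), compound 1 gives > 100000 nM, which is a limit of the assay and not a number.
Compound 2 `COc1ccc(-c2cc([C@@H]3O[C@H](CO)[C@@H](O)[C@H]3O)n3ncnc(N)c23)cc1`: in this assay compound 2 gives 40300 nM.

Within the data shown here, compound 2 thus holds the only real number in this assay; the other value recorded is a limit. Among the measured compounds shown here, the single measured step, an at least 2.4-fold lower number from compound 1 to compound 2 (0.39 log units; beyond the scatter), shows that changing the group on this aromatic carbon can shift the number at least modestly, though the limit of > 100000 nM in this assay, at which 1 of the 2 values shown sits, leaves its true size open. Compound 3 `Nc1ncnn2c([C@@H]3O[C@H](CO)[C@@H](O)[C@H]3O)cc(-c3ccsc3)c12` differs from compound 2 by thiophen-3-yl in place of 4-methoxyphenyl on an aromatic carbon. This is a different swap from the measured one, so the measured step is only a loose guide. The number for compound 3 is expected to sit near that of compound 2 or drift toward weaker inhibition, an expected step of a 1.7-fold higher number from compound 2 to compound 3 (0.24 log units; within the scatter). Compound 3 is estimated at 70000 nM, with a range from 25000 nM to 200000 nM.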

Compound 3, half-maximal inhibitory concentration: 57700 nM
For compound 3 the middle estimate is 1.2-fold (0.08 log units) above the measured one; low and high end bracket the measured number.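

In this assay, the step, a 1.4-fold higher number from compound 2 to compound 3 (0.16 log units; within the scatter), shows that this aromatic carbon accepts a five-membered aromatic ring holding sulfur in place of a six-membered ring of carbon only, with no difference beyond the scatter. The comparison with the 2-fluorophenyl group is less firm: the step, an at least 1.7-fold lower number from compound 1 to compound 3 (0.23 log units; that floor lies within the scatter), does not clearly separate the two groups. The value of compound 1 is a limit and not a number: the limit of > 100000 nM in this assay, at which 1 of the 3 values shown sits.

The compounds shown all carry an aromatic ring on this carbon, so it remains open whether an amine or a short alkyl chain such as ethyl there would give a clearly lower number. Going by these compounds, how a pyridine ring or a phenyl ring bearing a carboxylic acid would compare also remains open.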